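The compounds below may be only part of what the source reports. "The series", "measured", "known", "first", "only" and "open" are said of these compounds alone.

Compound 3 `Cc1cccc(N2CCN(C(=O)CN3C(=O)CC(C)(c4ccccc4)C3=O)CC2)c1` was tested in a functional assay on the whole organism (strain CD-1) with Mus musculus as the target, with a stated time of 2 h (on this read-out lower numbers stand for an effect already at smaller amounts and higher numbers for an effect only at larger amounts of compound), and is reported only as "not active" (no number reported), with no number at all. Two relatives give a sense of the scale on which compound 4 will be read: compound 1 `CC1(c2ccccc2)CC(=O)N(CC(=O)N2CCOCC2)C1=O` gives 300 mg/kg in this assay, and compound 2 `CC1(c2ccccc2)CC(=O)N(CC(=O)N2CCN(c3ccccc3Cl)CC2)C1=O` gives 100 mg/kg. Compound 4 `COc1ccccc1N1CCN(C(=O)CN2C(=O)CC(C)(c3ccccc3)C2=O)CC1` differs from compound 3 in one place: 2-methoxyphenyl in place of 3-methylphenyl on an amine nitrogen in a ring. For the measured compounds named here, no measured pair covers this change, so its size in this assay is open; if it helps, it can only move toward a measurable dose, and compound 2 with 100 mg/kg shows that a substituted phenyl on an amine nitrogen in a ring can go with such a dose. Compound 4 is expected to need about 300 mg/kg, between 100 mg/kg and 1000 mg/kg.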

Compound 4, minimum effective dose: "not active" (no number reported)
For compound 4 the study gives words and no number; there is nothing to compare the estimate with.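

Compound 3 and compound 4 are both reported only as "not active", without a number, so no step can be read between them. Going by these compounds, whether 2-methoxyphenyl and 3-methylphenyl differ in effect stays open. Nothing shown here explains the result.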